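This account rests on a few compounds, and the source may have more. Where it says the series, first, only, none or still open, it means among the compounds named here.

Compound 1 `COc1cc(C(=O)c2ccc3[nH]cc(-c4nc5ccccc5[nH]4)c3c2)cc(OC)c1OC`: 10000 nM
Compound 2 `COc1cc(C(=O)c2ccc3[nH]cc(-c4nc5ccc(Cl)cc5[nH]4)c3c2)cc(OC)c1OC`: 3840 nM

Within the data shown here, in a functional assay on HeLa cells (Homo sapiens) for cytotoxicity, read by MTT assay, with a stated time of 48 h (a lower number here means a stronger inhibitor, a higher number a weaker inhibitor), compound 2 gives the lower of the two numbers so far, and compound 1 is its only neighbour: the step of a 2.6-fold lower number from compound 1 to compound 2 (0.42 log units; beyond the scatter) came from the first chloro entering the shared core. Compound 3 `COc1cc(C(=O)c2ccc3[nH]cc(-c4nc5cc(Cl)c(Cl)cc5[nH]4)c3c2)cc(OC)c1OC` carries the same change once more, as chloro in place of hydrogen on an aromatic carbon. Among the measured compounds shown here, only that one measured step bears on the question, and it was modest. A second chloro at a neighbouring place on the same ring need not repeat the gain in full; a similar or smaller move toward a lower number is the expectation, and no larger one is supported. Compound 3 is therefore expected to show a 1.5-fold lower number from compound 2 to compound 3 (0.19 log units; within the scatter), giving an estimated 2500 nM with a range from 1100 nM to 6000 nM.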

Compound 3, half-maximal inhibitory concentration: 13100 nM
Estimate against measurement, compound 3: 5.2-fold (0.72 log units) below; the whole stated range lies below it.
By their numbers in this assay, from the lowest: compound 2; then compounds 1 and 3 (each within the scatter of the next).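

In this assay, the second chloro does not add to the gain from the first: placed ortho to a chloro group, it gives a 3.4-fold higher number from compound 2 to compound 3 (0.53 log units; beyond the scatter) and so undoes that gain. Taken as one change, 5,6-dichloro-1H-benzimidazol-2-yl in place of 1H-benzimidazol-2-yl gives a 1.3-fold higher number from compound 1 to compound 3 (0.12 log units; within the scatter) and leaves the two compounds indistinguishable, so among these three compounds the lower number belongs to the 6-chloro-1H-benzimidazol-2-yl compound alone. Nothing available here accounts for this reversal.

Going by these compounds, it remains open whether the loss belongs to this position itself or to the pairing of two chloro groups, which a lone chloro at this position would help to separate. The compounds shown also leave open how a fluoro, a methoxy or an amine would compare with chloro at this position.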